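Benzyl for Isopropyl on the Ether Oxygen: Cytotoxicity Outlook

The compounds below may be only part of what the source reports. "The series", "measured", "known", "first", "only" and "open" are said of these compounds alone.

Compound 1 `CC(C)N(Cc1cccc(OCCCCCC(=O)O)c1)C(=O)c1ccc(-c2cccc(OCc3ccccc3)c2)cc1` in an ADME assay on BJ cells (Homo sapiens) for cytotoxicity, read by CellTiter-Glo and resazurin assay, with a stated time of 72 h (a higher number here means that more compound is needed for the effect, a lower number that less compound is needed), gives > 26000 nM, a limit of the assay rather than a number.
Compound 2 `CCOC(=O)CCCCCOc1cccc(CN(C(=O)c2ccc(-c3cccc(C(C)=O)c3)cc2)C(C)C)c1` gives > 26000 nM, also a limit.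
Compound 3 `CCOC(=O)CCCCCOc1cccc(CN(C(=O)c2ccc(-c3cccc(OC(C)C)c3)cc2)C(C)C)c1` gives > 26000 nM, again a limit.

Compound 3 thus stands at the limit, where every value shown sits (the limit of > 26000 nM in this assay, at which 3 of the 3 values shown sit). Going by the values given here, the only single-point step, a step that the two limits leave unreadable from compound 2 to compound 3, cannot be read in size or direction, since both of its ends are limits. Compound 4 `CCOC(=O)CCCCCOc1cccc(CN(C(=O)c2ccc(-c3cccc(OCc4ccccc4)c3)cc2)C(C)C)c1` differs from compound 3 by benzyl in place of isopropyl on an oxygen on an aromatic ring. No readable measured step bears on this change, so with all three values at the limit no step beyond the scatter is expected. Compound 4 is estimated at 30000 nM, within 15000 nM to 100000 nM, an expected step that the limit leaves unreadable from compound 3 to compound 4.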

Compound 4, half-maximal effective concentration: > 26000 nM
Compound 4: only a limit was reported; the forecaster's own chance of this, stated with the estimate: 85%; the middle value lies beyond the limit too.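

Compound 4 gives only a limit, as do compound 1, compound 2 and compound 3, so no step among them can be read: the limit of > 26000 nM in this assay, at which 4 of the 4 values shown sit.

The compounds shown leave open which change to the shared core, if any, would give a measured number in this assay.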